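The source may hold more compounds than are shown below. What is called first, only, known or untested is meant among the compounds shown, and "the series" means these compounds.

Three compounds were tested in an ADME assay on HepG2 cells (Homo sapiens) for cytotoxicity, read by luminescence, CellTiter-Glo and ATP content, with a stated time of 72 h; a lower number here means that less compound is needed, a higher number that more compound is needed for the effect. Compound 1 `COc1cccc(CNCCCNc2ccnc3cc(Oc4ccccc4)ccc23)c1O` gives 6800 nM, compound 2 `COc1cccc(CNCCCNc2ccnc3cc(CC(C)C)ccc23)c1O` gives 2920 nM, and compound 3 `COc1ccc(F)cc1CNCCCNc1ccnc2cc(CC(C)C)ccc12` gives 2900 nM. Compound 1 differs from compound 2 by phenoxy in place of isobutyl on an aromatic carbon, and this change brought a 2.3-fold higher number from compound 2 to compound 1 (0.37 log units; beyond the scatter). Compound 3 differs from compound 2 by 5-fluoro-2-methoxyphenyl in place of 2-hydroxy-3-methoxyphenyl on a saturated chain carbon bound to an amine nitrogen, a change that gave a 1.0-fold lower number from compound 2 to compound 3 (0.00 log units; within the scatter). Compound 4 `COc1ccc(F)cc1CNCCCNc1ccnc2cc(Oc3ccccc3)ccc12` has not yet been measured; it differs from compound 3 by phenoxy in place of isobutyl on an aromatic carbon. This is the same change as from compound 2 to compound 1, made at the same place, and it occurs twice among these compounds, while the cores of compound 2 and compound 3 differ as just described. Compound 4 is expected to show a 2.3-fold higher number from compound 3 to compound 4 (0.36 log units; beyond the scatter) in this assay because the like change earlier gave a 2.3-fold higher number from compound 2 to compound 1 (0.37 log units; beyond the scatter). The estimate for compound 4 is therefore 6700 nM, expected to fall between 3500 nM and 13000 nM.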

Compound 4, half-maximal effective concentration: 1500 nM
Estimate against measurement, compound 4: 4.5-fold (0.65 log units) above, and the stated range ends above it.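

In this assay, phenoxy in place of isobutyl gave a 1.9-fold lower number from compound 3 to compound 4 (0.29 log units; within the scatter), so this change did not carry over unaltered from one core to the other: the same change on two cores in this assay, a 2.3-fold higher number (0.37 log units; beyond the scatter) from compound 2 to compound 1 and a 1.9-fold lower number (0.29 log units; within the scatter) from compound 3 to compound 4, 4.5-fold (0.65 log units) apart, beyond the scatter of two such steps. Seen from the other side, 5-fluoro-2-methoxyphenyl in place of 2-hydroxy-3-methoxyphenyl gave a 4.5-fold lower number from compound 1 to compound 4 (0.66 log units; beyond the scatter), so the effect of that change also depended on the group at the other place: the same change on two cores in this assay, a 1.0-fold lower number (0.00 log units; within the scatter) from compound 2 to compound 3 and a 4.5-fold lower number (0.66 log units; beyond the scatter) from compound 1 to compound 4, 4.5-fold (0.65 log units) apart, beyond the scatter of two such steps. The two changes therefore do not simply add up in these four compounds, but this set cannot show why, or whether the same holds elsewhere in the series.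

Going by these compounds, it remains open whether a cyclohexyl group or an amine on that aromatic carbon would behave in the same way. On these data alone, the effect of a longer chain bound to the amine nitrogen also remains open.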